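A few compounds are considered here, and "the series" means these few. Any claim that something is new, unique, unknown or untested is made for them only; others in the source may bear on it.

Three compounds built on one shared core have so far been examined in an assay on L cells for inhibition of Protein-serine O-palmitoleoyltransferase porcupine (Mus musculus), read by reporter gene assay, with a stated time of 24 h; on this read-out lower numbers stand for an effect already at smaller amounts and higher numbers for an effect only at larger amounts of compound. Compound 1 `O=C(CSc1nc2c(c(=O)n1-c1ccc(F)cc1)SCC2)Nc1nc2ccc(Cl)cc2s1` gives 175 nM in this assay, compound 2 `COc1ccccc1-n1c(SCC(=O)Nc2nc3ccc(Cl)cc3s2)nc2c(c1=O)SCC2` gives 50 nM, and compound 3 `COc1ccc(-n2c(SCC(=O)Nc3nc4ccc(OC)cc4s3)nc3c(c2=O)SCC3)cc1` gives 120 nM. Among these three numbers compound 3 stands second highest; its nearest neighbour is compound 1, whose number lies within the scatter of it, whereas the number of compound 2 lies beyond the scatter on the lower side.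

Within the data shown here, the only step between compounds that differ in one place is a 3.5-fold lower number from compound 1 to compound 2 (0.54 log units; beyond the scatter), an exchange of the aryl group on the aromatic nitrogen. Compound 4 `COc1ccc(-n2c(SCC(=O)Nc3nc4ccc(Cl)cc4s3)nc3c(c2=O)SCC3)cc1` differs from compound 3 at a different site: chloro in place of methoxy on an aromatic carbon. Among the measured compounds shown here, no measured step touches this position, so the step from compound 1 to compound 2 does not bear on it directly. What the data do show is that compound 1 and compound 2, both carrying the entering chloro group, have numbers on either side of compound 3. On that basis a step no larger than the scatter is expected in this assay, in either direction, written as a 1.2-fold lower number from compound 3 to compound 4 (0.08 log units; within the scatter). Compound 4 is therefore estimated at 100 nM, with a range from 40 nM to 250 nM.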

Compound 4, half-maximal effective concentration: 35 nM
For compound 4 the middle estimate is 2.9-fold (0.46 log units) above the measured one; the measured number lies below the stated range.
By their numbers in this assay, from the lowest: compounds 4 and 2 (each within the scatter of the next); then compounds 3 and 1 (each within the scatter of the next).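

In this assay, among these compounds, the exchange of 6-methoxy-1,3-benzothiazol-2-yl for 6-chloro-1,3-benzothiazol-2-yl gives the first measured step at this position, a 3.4-fold lower number from compound 3 to compound 4 (0.54 log units; beyond the scatter) and so the identity of this group matters at least with 4-methoxyphenyl on the aromatic nitrogen. With chloro held in place, methoxy in place of fluoro on the aryl group gives a 5.0-fold lower number from compound 1 to compound 4 (0.70 log units; beyond the scatter) while 4-methoxyphenyl in place of 2-methoxyphenyl gives a 1.4-fold lower number from compound 2 to compound 4 (0.15 log units; within the scatter) and so the two methoxyphenyl isomers cannot be told apart here. Nothing among the data given accounts for any of these steps.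

The compounds shown carry only methoxy or chloro on this aromatic carbon, so it remains open how a group such as methyl, nitrile or an amine would read there. Among the compounds shown here, the step from methoxy to chloro is also seen with only one aryl group, and whether it holds with 2-methoxyphenyl or 4-fluorophenyl on the aromatic nitrogen stays open.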